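Notes on a sulfamoyl nucleoside series in PBMC cells

The source may hold more compounds than are shown below. What is called first, only, known or untested is meant among the compounds shown, and "the series" means these compounds.

The series is followed in a functional assay on PBMC cells (Homo sapiens) for inhibition; a lower number here means a stronger inhibitor, a higher number a weaker inhibitor. Compound 1 `N=C(N)NCCC[C@H](N)C(=O)NS(=O)(=O)OC[C@H]1OC[C@@H](n2cnc3c(N)ncnc32)C[C@@H]1O` gives 600 nM in this assay, the lower of the two numbers recorded so far. Compound 2 `NC(=O)CC[C@H](N)C(=O)NS(=O)(=O)OC[C@H]1O[C@@H](n2cnc3c(N)ncnc32)[C@H](O)[C@@H]1O` gives 800 nM, a result that lies within the scatter of the value for compound 1, so no order between the two can be read from these figures.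

Compound 3 `Nc1ncnc2c1ncn2[C@@H]1CO[C@H](COS(=O)(=O)NC(=O)[C@@H]2CCCN2)[C@@H](O)C1` keeps the shared core of compound 1 and changes only the acyl part on the sulfamoyl nitrogen: a group of 5 heavy atoms (4 carbon, 1 nitrogen; one five-membered non-aromatic ring with 1 hetero atom) in place of a group of 9 heavy atoms (5 carbon, 4 nitrogen; no ring), on a carbonyl carbon

Within the data shown here, no measured pair in this set isolates such a change, so the size of the step cannot be read from the data. Given that both recorded values sit close together, the step from compound 1 to compound 3 in this assay is expected to be modest and toward a weaker inhibitor, a 2.5-fold higher number from compound 1 to compound 3 (0.40 log units; beyond the scatter). For compound 3 the expected value in this assay is 1500 nM, with a range from 300 nM to 8000 nM.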

Compound 3, half-maximal inhibitory concentration: 2800 nM
Beside the measured number, compound 3's estimate is 1.9-fold (0.27 log units) below it; the measured number falls inside the stated range.
By their numbers in this assay, from the lowest: compounds 1 and 2 (each within the scatter of the next); then compound 3.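

On the carbonyl carbon, pyrrolidin-2-yl in place of the open group of 9 heavy atoms gives a 4.7-fold higher number from compound 1 to compound 3 (0.67 log units; beyond the scatter) in this assay. Among these compounds, this is the first step that can be read from a single change, and it lies beyond the scatter, so the group at this place does affect the number while the shared core stays the same. No measurement shown bears on the reason for this step.

The compounds shown do not separate the presence of the ring from the smaller size of the entering group; an open 4-aminobutyl chain or a piperidin-2-yl ring on the same carbonyl carbon would speak to that. They also leave open how a chain ending in a carboxylic acid would compare with compound 1 at this place.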